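The source may hold more compounds than are shown below. What is called first, only, known or untested is meant among the compounds shown, and "the series" means these compounds.

Measured so far in a functional assay on SW480 cells (Homo sapiens) for inhibition, read by luminescence and resazurin assay, with a stated time of 3 days; a higher number here means a weaker inhibitor, a lower number a stronger inhibitor:

compound 1 `CNc1nc(NCc2ccc(C(=O)Nc3ccc(F)cc3)cc2)c2ccccc2n1`: 4100 nM
compound 2 `CCNc1nc(NCc2ccc(C(=O)Nc3ccc(F)cc3)cc2)c2ccccc2n1`: 2500 nM
compound 3 `CN(C)c1nc(NCc2ccc(C(=O)Nc3ccc(F)cc3)cc2)c2ccccc2n1`: 2600 nM

Compound 3 stands second highest of the three numbers in this assay; its nearest neighbour is compound 2 and its furthest is compound 1, and both gaps are within the scatter. The next compound, compound 4 `C=CCNc1nc(NCc2ccc(C(=O)Nc3ccc(F)cc3)cc2)c2ccccc2n1`, carries the change (allylamino in place of dimethylamino on an aromatic carbon). Going by the values given here, the steps that bear on this are the earlier variations of the same amino group: a 1.6-fold lower number from compound 1 to compound 2 (0.21 log units; within the scatter), a 1.6-fold lower number from compound 1 to compound 3 (0.20 log units; within the scatter) and a 1.0-fold higher number from compound 2 to compound 3 (0.02 log units; within the scatter). All three are within the scatter, so the series shows no response of this assay to the size or substitution of this amino group so far; compounds 1, 2 and 3 all sit in the same band. An allylamino group is a further small change of the same kind, so compound 4 is expected to show no step beyond the scatter, a 1.1-fold lower number from compound 3 to compound 4 (0.05 log units; within the scatter). Compound 4 is therefore estimated at 2300 nM, in the range 1000 nM to 5500 nM.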

Compound 4, half-maximal inhibitory concentration: 11000 nM
Compound 4: the middle estimate sits 4.8-fold (0.68 log units) below what was measured; measured number above the stated range.
By their numbers in this assay, from the lowest: compounds 2, 3 and 1 (each within the scatter of the next); then compound 4.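

Allylamino is the first group at this position, between two ring nitrogen atoms, to move the number in this assay beyond the scatter, with a 4.2-fold higher number from compound 3 to compound 4 (0.63 log units; beyond the scatter) on replacing dimethylamino. The two other comparisons run the same way, with vinyl in place of methyl giving a 4.4-fold higher number from compound 2 to compound 4 (0.64 log units; beyond the scatter) and vinyl in place of hydrogen giving a 2.7-fold higher number from compound 1 to compound 4 (0.43 log units; beyond the scatter), so the position does respond to the amino group, and the shared band of compound 1, compound 2 and compound 3 does not extend to compound 4. Nothing available here accounts for this step.

As far as these compounds go, whether the higher number goes with the double bond or with the chain length stays open, and a propylamino group, the same chain without the double bond, would separate the two. From the compounds shown here alone, how a propargylamino group or a longer chain such as butylamino would read at this position is also open.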